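The compounds below may be only part of what the source reports. "The series", "measured", "known", "first", "only" and "open" are said of these compounds alone.

Measured in an ADME assay on L6 cells (Rattus norvegicus) for cytotoxicity; a higher number here means a weaker inhibitor, a lower number a stronger inhibitor:
- compound 1 `CC(C)NC(=N)c1ccc(-c2cc3cc(C(=N)NC(C)C)ccc3o2)cc1` gives > 198000 nM
- compound 2 `c1cc(-c2cc3ccc(C4=NCCN4)cc3o2)ccc1C1=NCCN1` gives 4500 nM

Compound 1 is known only as a limit (> 198000 nM), not as a number. Compound 3 `CC(C)NC(=N)c1ccc(-c2cc3cc(C(=N)NC(C)C)cc(O)c3o2)cc1` keeps the core of compound 1 with a single change (hydroxy in place of hydrogen on an aromatic carbon), hydroxy in place of hydrogen on an aromatic carbon. Among the compounds with values here, no measured pair shows this change. The expected step of an at least 1.9-fold lower number from compound 1 to compound 3 (0.29 log units; that floor lies within the scatter) is modest, towards a stronger inhibitor in this assay, and the assay may again report only a limit. Compound 3 is estimated at 100000 nM (expected range 25000 nM to 250000 nM).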

Compound 3, half-maximal inhibitory concentration: > 185000 nM
Compound 3 was reported as a limit; the forecaster's own chance of this, stated with the estimate: 35%; middle value at least 1.8-fold (0.26 log units) away from the limit.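

In this assay compound 1 and compound 3 both stand only as limits, and no step can be read between them. The compounds shown leave open whether hydroxy in place of hydrogen on an aromatic carbon shifts the half-maximal inhibitory concentration at all.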